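The source may report more compounds than this note shows. Statements on the series, on what has been measured and on what is new or still open speak of the compounds shown alone.

Working notes on the series. Compound 1 `CCc1ccccc1-n1nncc1CN1C(=O)C2(C(C#N)=C(N)Oc3c(N)cc4nc5ccccc5nc4c32)c2ccccc21` in a functional assay on MCF7 cells (Homo sapiens) for antiproliferative activity, read by MTT assay, with a stated time of 48 h (on this read-out higher numbers stand for weaker inhibition and lower numbers for stronger inhibition), gives 24600 nM. Compound 2 `N#CC1=C(N)Oc2c(N)cc3nc4ccccc4nc3c2C12C(=O)N(Cc1cnnn1-c1ccccc1Cl)c1ccccc12` in this assay gives 34400 nM, and the step of a 1.4-fold higher number from compound 1 to compound 2 (0.15 log units; within the scatter) is small. Compound 3 `N#CC1=C(N)Oc2c(N)cc3nc4ccccc4nc3c2C12C(=O)N(Cc1cnnn1-c1cccc(Br)c1)c1ccccc12` in this assay gives only a limit, > 50000 nM. Compound 3 therefore stands at the limit of > 50000 nM in this assay, at which 1 of the 3 values shown sits, with no number of its own. The steps of an at least 2.0-fold higher number from compound 1 to compound 3 (0.30 log units; that floor lies within the scatter) and an at least 1.4-fold higher number from compound 2 to compound 3 (0.16 log units; that floor lies within the scatter) are floors that lie within the scatter, so compound 3 is not separated from the other two. Compound 4 `COc1ccc(-n2nncc2CN2C(=O)C3(C(C#N)=C(N)Oc4c(N)cc5nc6ccccc6nc5c43)c3ccccc32)cc1` differs from compound 3 by 4-methoxyphenyl in place of 3-bromophenyl on an aromatic nitrogen. Going by the values given here, no measured step involves a methoxy group on this phenyl; the two steps that reach compound 3 replaced 2-ethylphenyl or 2-chlorophenyl with 3-bromophenyl, and neither produced a step beyond the scatter. Across the three measured compounds the numbers sit in a narrow band, so no step beyond the scatter is expected in this assay for compound 4. Compound 4 is estimated at 40000 nM, with a range from 15000 nM to 100000 nM, which means an expected step of an at least 1.2-fold lower number from compound 3 to compound 4 (0.09 log units; that floor lies within the scatter).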

Compound 4, half-maximal inhibitory concentration: > 50000 nM
Compound 4 was reported as a limit; the forecaster's own chance of this, stated with the estimate: 40%; at least 1.2-fold (0.09 log units) between middle value and limit.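

In this assay compound 4 is also reported only as a limit, so 4-methoxyphenyl on the aromatic nitrogen, which adds a hydrogen-bond acceptor that 3-bromophenyl lacks, gives no value of its own, and a second phenyl group now sits at this limit: the limit of > 50000 nM in this assay, at which 2 of the 4 values shown sit.

The readable steps are an at least 1.4-fold higher number from compound 2 to compound 4 (0.16 log units; that floor lies within the scatter) and an at least 2.0-fold higher number from compound 1 to compound 4 (0.30 log units; that floor lies within the scatter), and neither separates the pair it joins. The step that joins compound 3 and compound 4 cannot be read, since both values are limits.

As far as these compounds go, it remains open whether any group on this phenyl gives a step beyond the scatter in this assay, and where compound 3 and compound 4 lie beyond their limits. An amine or a carboxylic acid on this phenyl, or a longer chain in place of the methoxy group, would bear on that question.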